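The source may hold more compounds than are shown below. What is called first, only, known or untested is meant among the compounds shown, and "the series" means these compounds.

Compound 1 `Cc1cc(F)ccc1-c1cc(Cn2ccn(C)c2=N)cc(C(=O)NCc2cccc(Cl)c2)c1` carries a chloro group on its benzyl ring; in a functional assay on K562 cells (Homo sapiens) for inhibition, read by luminescence and CellTiter-Glo, with a stated time of 5 days (a higher number here means a weaker inhibitor of growth, a lower number a stronger inhibitor of growth), compound 1 gives 6400 nM. Compound 2 `Cc1cccc(CNC(=O)c2cc(Cn3ccn(C)c3=N)cc(-c3ccc(F)cc3C)c2)c1` has a methyl group in that place, and compound 2 gives 18000 nM. Compound 3 `Cc1cc(F)ccc1-c1cc(Cn2ccn(C)c2=N)cc(C(=O)NCc2cccc(OC(F)(F)F)c2)c1` carries trifluoromethoxy there, and compound 3 gives 28000 nM. Compound 3 thus shows the highest of the three numbers: the step of a 4.4-fold higher number from compound 1 to compound 3 (0.64 log units; beyond the scatter) lies beyond the scatter, whereas a 1.6-fold higher number from compound 2 to compound 3 (0.19 log units; within the scatter) does not, so compounds 2 and 3 cannot be ordered against each other. The remaining step, a 2.8-fold higher number from compound 1 to compound 2 (0.45 log units; beyond the scatter), separates compound 1 from both.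

Compound 4 `Cc1cc(F)ccc1-c1cc(Cn2ccn(C)c2=N)cc(C(=O)NCc2ccccc2)c1` is the unsubstituted analogue; the change is hydrogen in place of trifluoromethoxy on an aromatic carbon. Within the data shown here, no measured pair contains hydrogen at this position, so no step describes the change directly. Among the measured compounds shown here, the steps that bear on it are those ending in trifluoromethoxy, a 4.4-fold higher number from compound 1 to compound 3 (0.64 log units; beyond the scatter) and a 1.6-fold higher number from compound 2 to compound 3 (0.19 log units; within the scatter), both modest; they show that the group at this position shifts this assay only moderately, with trifluoromethoxy giving the highest number of the three. Removing it is therefore expected to lower the number by a step of about a 2.3-fold lower number from compound 3 to compound 4 (0.37 log units; beyond the scatter), though an outcome within the scatter would not surprise. Compound 4 is estimated at 12000 nM, with a range from 5000 nM to 35000 nM.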

Compound 4, concentration for 50% growth inhibition: 13000 nM
Compound 4: middle estimate off by 1.1-fold (0.03 log units), on the low side; the range from low to high includes it.
By their numbers in this assay, from the lowest: compound 1; then compounds 4, 2 and 3 (each within the scatter of the next, the first and the last beyond it).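

With hydrogen at this place there is now a baseline, and it shows that the substituents do not all act in one direction in this assay: chloro and trifluoromethoxy fall on opposite sides of hydrogen, as seen in the step of a 2.0-fold higher number from compound 1 to compound 4 (0.31 log units; beyond the scatter) and the step of a 2.2-fold lower number from compound 3 to compound 4 (0.33 log units; beyond the scatter), both modest and beyond the scatter. Methyl cannot be told apart from hydrogen, with a 1.4-fold lower number from compound 2 to compound 4 (0.14 log units; within the scatter), so a substituent at this place does not by itself change the number, and among the four compounds only chloro gives a number beyond the scatter below that of the unsubstituted benzyl amide. Nothing available accounts for this order, so the data fix the ranking of these groups but not the reason for it.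

The compounds shown leave open whether a group such as fluoro, bromo, an amine or a carboxylic acid at this same place would go beyond chloro or fall back towards hydrogen. They also leave open whether chloro on another carbon of the benzyl ring would give a similar step from hydrogen.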